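The source may report more compounds than this note shows. Statements on the series, on what has been measured and on what is new or still open speak of the compounds shown alone.

Compound 1 `COC(=O)c1ccccc1-c1ccc(CN2C(=O)[C@H](NC(=O)CC(C)(C)N)CCc3ccccc32)cc1`: 2 uM
Compound 2 `CC(C)(N)CC(=O)N[C@@H]1CCc2ccccc2N(Cc2ccc(-c3ccccc3C#N)cc2)C1=O`: 5 uM

For the measured compounds named here, in a functional assay (Pituitary gland cell) with Rattus norvegicus as the target (a higher number here means that more compound is needed for the effect, a lower number that less compound is needed), compound 1 gives 2 uM while compound 2 gives 5 uM, so compound 2 has the higher of the two numbers, and the single measured step, a 2.5-fold higher number from compound 1 to compound 2 (0.40 log units; beyond the scatter), separates them by more than the scatter. Compound 3 `CC(C)(N)CC(=O)N[C@@H]1CCc2ccccc2N(Cc2ccc(-c3ccccc3S(=O)(=O)NC(=O)c3ccccc3)cc2)C1=O` differs from compound 2 by benzoylsulfamoyl in place of cyano on an aromatic carbon. Going by the values given here, the one measured step touches the same aromatic carbon, but it exchanged cyano for methoxycarbonyl, so it bears only loosely on the new group; its size was modest, and the non-cyano partner, compound 1, gave the lower number. On that slender basis a small change, if any, in this assay is expected, and compound 3 is estimated at 3 uM, from 0.8 uM to 12 uM, meaning a 1.7-fold lower number from compound 2 to compound 3 (0.22 log units; within the scatter).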

Compound 3, concentration for half-maximal effect: 3 uM
For compound 3 middle estimate and measured number coincide at the digits printed; low and high end bracket the measured number.
By their numbers in this assay, from the lowest: compounds 1, 3 and 2 (each within the scatter of the next, the first and the last beyond it).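

On the aromatic carbon ortho to a large group, the small cyano can be exchanged for the much larger benzoylsulfamoyl, which brings a six-membered aromatic ring of its own, and this assay records a 1.7-fold lower number from compound 2 to compound 3 (0.22 log units; within the scatter) for that exchange. Replacing methoxycarbonyl at the same carbon with benzoylsulfamoyl gives a 1.5-fold higher number from compound 1 to compound 3 (0.18 log units; within the scatter), so the new group cannot be told apart from either earlier group here, although compound 1 and compound 2 differ from each other by more than the scatter. Nothing at hand explains this outcome.

As far as these compounds go, it remains open whether a carboxylic acid or an amine on this carbon would give a number in the same range. From the compounds shown here alone, it is also open whether the benzoyl part matters, since a plain sulfamoyl group would be needed to compare with compound 3.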